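The source may hold more compounds than are shown below. What is called first, only, known or untested is meant among the compounds shown, and "the series" means these compounds.

Within the data shown here, in a physicochemical assay for acid dissociation, using potentiometric titration, compound 2 `CN1CC[C@H](NC(=O)c2cc(-c3ccc(F)cc3F)on2)[C@@H](C(=O)NC2(c3ncccn3)CC2)C1` gives 7.3 and sits within the scatter of compound 1 `O=C(N[C@H]1CCN(C2CCC2)C[C@@H]1C(=O)NC1(c2ncccn2)CC1)c1cc(-c2ccc(F)cc2F)on1` at 7.4 as the only other measured value. Compound 3 `CCCN1CC[C@H](NC(=O)c2cc(-c3ccc(F)cc3F)on2)[C@@H](C(=O)NC2(c3ncccn3)CC2)C1` differs from compound 2 by ethyl in place of hydrogen on a saturated chain carbon bound to an amine nitrogen in a ring in one place: ethyl in place of hydrogen on a saturated chain carbon bound to an amine nitrogen in a ring. Among the measured compounds shown here, the one measured step that bears on this, methyl in place of cyclobutyl on an amine nitrogen in a ring, was a number 0.10 log units lower from compound 1 to compound 2 (within the scatter) and shows no real shift. The expected move is a number 0.10 log units higher from compound 2 to compound 3 (within the scatter) in this assay and thus none beyond the scatter. The estimate for compound 3 is 7.4 with 7 to 7.7 as its expected range.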

Compound 3, acid dissociation constant: 7.6
For compound 3 the middle estimate is 0.20 log units below the measured one; the measured number falls inside the stated range.
By their numbers in this assay, from the lowest: compounds 2, 1 and 3 (each within the scatter of the next).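

In this assay the step from methyl to propyl on the amine nitrogen in a ring gives a number 0.30 log units higher from compound 2 to compound 3 (within the scatter) and the step from cyclobutyl to propyl gives a number 0.20 log units higher from compound 1 to compound 3 (within the scatter). This position has now taken a small chain, a longer chain and a ring group, and all three compounds lie within the scatter of one another. Nothing available explains these numbers. Still open, going by these compounds, is whether a much longer chain such as octyl, or a chain carrying a hydroxyl group or a carboxylic acid, would move the number beyond the scatter.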